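Shortening an Alkenyl Chain on a Second Core

This account rests on a few compounds, and the source may have more. Where it says the series, first, only, none or still open, it means among the compounds named here.

Compound 2 `C=CCCCCOc1ncc(-c2ccccc2OC)n1C` and compound 1 `C=CCCOc1ncc(-c2ccccc2OC)n1C` share one core and differ in a single chain. In a functional assay on LoVo cells (Homo sapiens) for inhibition, read by colorimetric assay and MTT assay, with a stated time of 72 h (on this read-out lower numbers stand for stronger inhibition and higher numbers for weaker inhibition), compound 2 gives 4000 nM, and compound 1 gives 24000 nM. The change between them, (vinyl in place of but-3-en-1-yl on a saturated chain carbon, two bonds along the chain from an oxygen on an aromatic ring), made a step of a 6.0-fold higher number from compound 2 to compound 1 (0.78 log units; beyond the scatter), so the shorter chain went with weaker inhibition.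

Compound 3 `C=CCCCCOc1ccccc1-c1cnc(S(=O)(=O)c2ccccc2)n1C` carries the same but-3-en-1-yl chain on a different core; the difference between the two cores is not broken down here. In this assay compound 3 gives 27000 nM, close to the value of compound 1 and a higher number than compound 2. Compound 4 `C=CCCOc1ccccc1-c1cnc(S(=O)(=O)c2ccccc2)n1C` is made from compound 3 by the same change, (vinyl in place of but-3-en-1-yl on a saturated chain carbon, two bonds along the chain from an oxygen on an aromatic ring), at the same place.

Within the data shown here, the only measured example of this change is a 6.0-fold higher number from compound 2 to compound 1 (0.78 log units; beyond the scatter), a step beyond the scatter, but it was seen on a core whose difference from the core of compound 3 is not broken down here, so its size may not carry over exactly. Compound 4 is therefore expected to move by a 4.1-fold higher number from compound 3 to compound 4 (0.61 log units; beyond the scatter). In this assay compound 4 is estimated at 110000 nM, within 30000 nM to 400000 nM.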

Compound 4, half-maximal inhibitory concentration: 32000 nM
The estimate for compound 4 lay 3.4-fold (0.54 log units) above the measured number; low and high end bracket the measured number.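

In this assay the shorter chain on the core of compound 3 gave a 1.2-fold higher number from compound 3 to compound 4 (0.07 log units; within the scatter) and so produced no change that can be told apart from the usual spread of repeated measurements. The effect of this change therefore did not carry over in size from one core to the other: the same change on two cores in this assay, a 6.0-fold higher number (0.78 log units; beyond the scatter) from compound 2 to compound 1 and a 1.2-fold higher number (0.07 log units; within the scatter) from compound 3 to compound 4, 5.1-fold (0.70 log units) apart, beyond the scatter of two such steps

This shows that a step measured on one core in this series can be a poor guide to the same step on another core, but with only these two pairs it does not show which feature of the cores separates them or what the change would do on a third core.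

As far as these compounds go, it remains open whether a longer chain than hex-5-en-1-yl would give a clearer step on either core, and whether an amine or a carboxylic acid at the end of the chain would do so. Also open, from the compounds shown here alone, is which part of the difference between the two cores governs the size of the step.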